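From methoxy to nitro: compound 2 and compound 3

The source may hold more compounds than are shown below. What is called first, only, known or untested is meant among the compounds shown, and "the series" means these compounds.

Compound 1 `CC(C)(C)NCc1c(C(=O)O)nn(-c2ccc(Cl)cc2)c1-c1ccccc1` gives > 652000 nM as a limit
Compound 2 `COc1ccc(-c2c(CNC(C)(C)C)c(C(=O)O)nn2-c2ccc(Cl)cc2)cc1` gives > 605000 nM as a limit
Compound 3 `CC(C)(C)NCc1c(C(=O)O)nn(-c2ccc(Cl)cc2)c1-c1ccc([N+](=O)[O-])cc1` has not yet been measured

In a functional assay on PC-3 cells (Homo sapiens) for inhibition, read by sulforhodamine B assay, with a stated time of 48 h (on this read-out higher numbers stand for weaker inhibition of growth and lower numbers for stronger inhibition of growth), compound 2 stands at > 605000 nM as a limit and has no number of its own. The change to compound 3 is nitro in place of methoxy on an aromatic carbon and, in words, it is nitro in place of methoxy on an aromatic carbon. Within the data shown here, one measured step bears on this, a step that the two limits leave unreadable from compound 1 to compound 2 and it is methoxy in place of hydrogen on an aromatic carbon. Both ends of that step are limits, so it offers no size to carry over. No step beyond the scatter is therefore expected in either direction, and another limit is the likeliest outcome in this assay for compound 3. The expected change is a number no higher from compound 2 to compound 3 (the limit leaves the size open) and this is only an estimate. Compound 3 is estimated at 600000 nM with an expected range from 200000 nM to 1000000 nM in this read-out.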

Compound 3, concentration for 50% growth inhibition: > 583000 nM
Compound 3: no number, only a limit; the forecaster's own chance of this, stated with the estimate: 85%; the middle value does not contradict the limit.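

In this assay compound 3 gives > 583000 nM, which is a limit and not a number. Its steps from compound 1 and from compound 2 therefore cannot be read, as those values are limits too. The compounds shown leave open what growth-inhibiting concentration any of them actually has, and whether methoxy or nitro changes it at all.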